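A few compounds are considered here, and "the series" means these few. Any claim that something is new, unique, unknown or untested is made for them only; others in the source may bear on it.

In an ADME assay on cells (spleen, Mus musculus, strain C57BL/6) for inhibition, read by flow cytometry and propidium iodide staining, with a stated time of 24 h, at 37 degrees C (on this read-out lower numbers stand for an effect already at smaller amounts and higher numbers for an effect only at larger amounts of compound), three relatives of the unmeasured compound have been tested. Compound 2 `O=C(Cn1cc(C(=O)O)nn1)NCc1ccccc1` has no single number and is recorded only as "non-toxic" (no number reported), so it cannot be placed exactly on the scale. Compound 1 `CC(C)(O)c1cn(CC(=O)NCc2ccccc2)nn1` gives 1600 uM. Compound 3 `CC(C)(C)OC(=O)NCc1cn(CC(=O)NCc2ccccc2)nn1` reaches only a limit of the assay, > 2000 uM.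

The next compound to be measured is compound 4 `Nc1ccc(-c2cn(CC(=O)NCc3ccccc3)nn2)cc1`. The structural change is 4-aminophenyl in place of carboxy on an aromatic carbon, with 4-aminophenyl in place of carboxy on an aromatic carbon of a five-membered aromatic ring with 3 nitrogen.

No measured step connects any of these compounds, and without a number for compound 2 the size of this change cannot be counted from its starting point. In this assay, a moderate move toward lower numbers is nevertheless expected, although a result that stays at the top of the measurable range would not be surprising. This expectation rests on compound 1, which has no carboxy and gives 1600 uM. Compound 3 also has no carboxy, and it offers no number to support the expectation, since its > 2000 uM is a limit. For compound 4, the expected value is 900 uM, with an estimated range from 200 uM to 2500 uM.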

Compound 4, concentration for half-maximal effect: 1240 uM
Beside the measured number, compound 4's estimate is 1.4-fold (0.14 log units) below it; low and high end bracket the measured number.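

In this assay, 4-aminophenyl in place of 1-hydroxy-1-methylethyl on the aromatic carbon gives a 1.3-fold lower number from compound 1 to compound 4 (0.11 log units; within the scatter). This place in the shared core therefore carries a group with 7 heavy atoms and a six-membered aromatic ring of carbon only, and the number of compound 4 cannot be told apart from that of compound 1. Compound 2 has no number and compound 3 stands at a limit of the assay, so the steps that touch them cannot be read, and the one readable step stays at the upper end of the scale, where one compound already rests: the limit of > 2000 uM in this assay, at which 1 of the 4 values shown sits.

The compounds shown leave open what the amine of the 4-aminophenyl group contributes, for which a phenyl group on this aromatic carbon would be the direct comparison. They also leave open whether a methyl group or a longer chain at this place would separate from compound 1 by more than the usual scatter.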